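Ethynyl for phenyl on a shared nucleoside core

The source may hold more compounds than are shown below. What is called first, only, known or untested is meant among the compounds shown, and "the series" means these compounds.

Working notes. Compound 3 `CNc1ncnc2c1c(-c1ccccc1)cn2[C@@H]1O[C@H](CO)[C@@H](O)[C@H]1O` carries phenyl and methylamino on the shared core; compound 1 `C#Cc1cn([C@@H]2O[C@H](CO)[C@@H](O)[C@H]2O)c2ncnc(NC)c12` carries ethynyl in place of that phenyl; compound 2 `COc1ncnc2c1c(-c1ccccc1)cn2[C@@H]1O[C@H](CO)[C@@H](O)[C@H]1O` keeps phenyl and has methoxy instead of methylamino. In a functional assay on HCT-116 cells (Homo sapiens), read by MTT assay, with a stated time of 72 h (a lower number here means a stronger inhibitor, a higher number a weaker inhibitor), compound 3 gives > 20000 nM, which is a limit of the assay. Compound 1 in this assay gives > 20000 nM, also a limit. Compound 2 gives > 20000 nM, again a limit. Accordingly the step that the two limits leave unreadable from compound 3 to compound 1 and the step that the two limits leave unreadable from compound 2 to compound 3 cannot be sized; all three values sit at the limit of > 20000 nM in this assay, at which 3 of the 3 values shown sit.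

The measured change from compound 3 to compound 1 is ethynyl in place of phenyl on an aromatic carbon. The same change, at the same place, turns compound 2 into compound 4 `C#Cc1cn([C@@H]2O[C@H](CO)[C@@H](O)[C@H]2O)c2ncnc(OC)c12`: ethynyl in place of phenyl on an aromatic carbon. The two cores differ by methoxy in place of methylamino on an aromatic carbon.

Nothing seen so far leaves the limit, so compound 4 is expected to remain at the limit as well. The expected step is a step that the limit leaves unreadable from compound 2 to compound 4. Compound 4 is estimated at 25000 nM in this assay, within 10000 nM to 60000 nM.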

Compound 4, half-maximal inhibitory concentration: 4060 nM
The estimate for compound 4 lay 6.2-fold (0.79 log units) above the measured number; measured number outside the range, below it.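

In this assay ethynyl in place of phenyl gives an at least 4.9-fold lower number from compound 2 to compound 4 (0.69 log units; beyond the scatter), so with methoxy on the shared core this change moves the number off the limit, and methoxy in place of methylamino with ethynyl on the core gives an at least 4.9-fold lower number from compound 1 to compound 4 (0.69 log units; beyond the scatter). The steps from compound 3 to compound 1 and from compound 2 to compound 3 cannot be read, so nothing shows whether the ethynyl change has any effect with methylamino on the core, and its carrying over from one core to the other is neither confirmed nor refuted. The two readable steps are lower bounds rather than sizes, and only compound 4 has a number to work from: the limit of > 20000 nM in this assay, at which 3 of the 4 values shown sit.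

Open, as far as these compounds go, is whether a nitrile or a longer alkyne chain in the place of ethynyl, with methoxy kept, also stays off the limit. Equally open, from the compounds shown here alone, is whether a plain amino group or a methyl group in the place of methoxy, with ethynyl kept, would do so.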